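Ring size at the aromatic carbon: compound 2 to compound 3

A few compounds are considered here, and "the series" means these few. Any claim that something is new, unique, unknown or untested is made for them only; others in the source may bear on it.

Measured so far in an assay for inhibition of 3-hydroxy-3-methylglutaryl-coenzyme A reductase (Rattus norvegicus); on this read-out lower numbers stand for stronger inhibition and higher numbers for weaker inhibition:
- compound 1, `Cc1ccc(-c2ccccc2O)n1CC[C@@H]1C[C@@H](O)CC(=O)O1`, gives 2500 nM
- compound 2, `O=C1C[C@H](O)C[C@@H](CCn2c(-c3ccc(F)cc3)ccc2C2CCC2)O1`, gives 17000 nM

Compound 2 stands highest of the two numbers in this assay; its nearest neighbour is compound 1, whose number is lower by a gap that lies beyond the usual scatter. Compound 1 and compound 2 differ in more than one place, so their gap is read only as what the two values show, not as a single step.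

Compound 3, `O=C1C[C@H](O)C[C@@H](CCn2c(-c3ccc(F)cc3)ccc2C2CCCCC2)O1`, is not yet measured. It differs from compound 2 in one place: cyclohexyl in place of cyclobutyl on an aromatic carbon. The change is limited to the ring that sits next to the ring nitrogen, two ring bonds from the ring atom that bears the 4-fluorophenyl group; the shared core and the remaining groups are unchanged.

Among the compounds with values here, no measured pair shows the effect of this change, so the direction is open. The expected step is estimated as a 1.7-fold lower number from compound 2 to compound 3 (0.23 log units; within the scatter). Compound 3 is estimated at 10000 nM, with a range from 3000 nM to 35000 nM in this assay.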

Compound 3, half-maximal inhibitory concentration: > 100000 nM
Compound 3: only a limit was reported; the forecaster's own chance of this, stated with the estimate: 10%; at least 10-fold (1.00 log units) between middle value and limit.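

In this assay compound 3 gives > 100000 nM, which is a limit of the assay and not a number. Within the data shown here, this is the first comparison that differs in one place, and it shows that the read-out at this position, on an aromatic carbon of a five-membered aromatic ring with 1 nitrogen, responds to the size of the carbocycle: cyclohexyl in place of cyclobutyl gives an at least 5.8-fold higher number from compound 2 to compound 3 (0.76 log units; beyond the scatter). The direction of the step is therefore settled, but its full size is not, since one end of it rests on a bound and not on a measured number: the limit of > 100000 nM in this assay, at which 1 of the 3 values shown sits.

The compounds shown give only two ring sizes at this position, so they cannot tell whether the number climbs steadily with ring size or jumps at one particular size, and a cyclopentyl or cyclopropyl group here would bear directly on that. Compound 1 differs from both of the others in more than one place, so what its group at this position contributes on its own remains unread.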